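Three stereoisomers at the limit, a fourth inversion considered

The source may hold more compounds than are shown below. What is called first, only, known or untested is meant among the compounds shown, and "the series" means these compounds.

Compound 2, `O=C(O)[C@@H](CO)NC(=O)[C@H]1C[C@@H](O)CN1`, stands in an ADME assay for metabolic stability, read by HPLC, in simulated intestinal fluid, with a stated time of 12 h, at pH 6.8 (on this read-out lower numbers stand for a shorter-lived compound and higher numbers for a longer-lived compound), at > 12 h, a limit of the assay rather than a number. Compound 1, `O=C(O)[C@H](CO)NC(=O)[C@H]1C[C@H](O)CN1`, gives > 12 h, likewise a limit. Compound 3, `O=C(N[C@H](CO)C(=O)O)[C@@H]1C[C@H](O)CN1`, gives > 12 h, also a limit. The steps a step that the two limits leave unreadable from compound 1 to compound 2, a step that the two limits leave unreadable from compound 1 to compound 3 and a step that the two limits leave unreadable from compound 2 to compound 3 are therefore unreadable because of the limit of > 12 h in this assay, at which 3 of the 3 values shown sit. Compound 4, `O=C(O)[C@H](CO)NC(=O)[C@H]1C[C@@H](O)CN1`, is not yet measured; its change from compound 2 is the two compounds have the same atoms and bonds and differ only in configuration as drawn: 1 of 3 stereo elements differ; a stereocentre at a saturated chain carbon is drawn R in compound 2 and S in compound 4. All three stereoisomers reaching the limit bear on it, but none gives a readable size, so no step beyond the scatter is expected and compound 4 is estimated at 12 h, between 6 h and 12 h, an expected step of a number no higher from compound 2 to compound 4 (the limit leaves the size open).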

Compound 4, half-life: > 12 h
Compound 4: no number, only a limit; the forecaster's own chance of this, stated with the estimate: 85%; the middle value lies on the limit itself.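

The steps linking compound 4 to compound 1, compound 2 and compound 3 cannot be read, because all four compounds sit at a limit: the limit of > 12 h in this assay, at which 4 of the 4 values shown sit.

On these data alone, how long each of these stereoisomers actually lasts in this assay, and whether configuration alters that at all, stays open.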